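A few compounds are considered here, and "the series" means these few. Any claim that something is new, unique, unknown or untested is made for them only; others in the source may bear on it.

Measured in a functional assay on SF-539 cells (Homo sapiens) for inhibition, read by colorimetric assay and sulforhodamine B assay, with a stated time of 48 h; a higher number here means a weaker inhibitor of growth, a lower number a stronger inhibitor of growth:
Compound 1 `CCCCCCCCCCCC[C@@H](O)[C@H]1CC[C@H]([C@H](O)CCCCCCCCCCNC(=O)c2cccs2)O1` gives 17000 nM
Compound 2 `CCCCCCCCCCCC[C@@H](O)[C@H]1CC[C@H]([C@H](O)CCCCCCCCCCNC(=O)c2ccoc2)O1` gives 100000 nM
Compound 3 `CCCCCCCCCCCC[C@@H](O)[C@H]1CC[C@H]([C@H](O)CCCCCCCCCCNC(=O)c2cncs2)O1` gives 50100 nM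

Compound 3 stands high among these numbers, with a 2.0-fold lower number from compound 2 to compound 3 (0.30 log units; within the scatter) and a 2.9-fold higher number from compound 1 to compound 3 (0.47 log units; beyond the scatter). Compound 4 `CCCCCCCCCCCC[C@@H](O)[C@H]1CC[C@H]([C@H](O)CCCCCCCCCCNC(=O)c2ccsc2)O1` alters one group of compound 3: thiophen-3-yl in place of 1,3-thiazol-5-yl on a carbonyl carbon. Within the data shown here, no measured step makes this exact exchange. The nearest guide is the modest step from thiophen-2-yl to 1,3-thiazol-5-yl, and a partial reversal of it is expected in this assay. Caution comes from a 5.9-fold higher number from compound 1 to compound 2 (0.77 log units; beyond the scatter), which shows that a change of ring can cost more. The expected step is a 2.1-fold lower number from compound 3 to compound 4 (0.32 log units; beyond the scatter). Compound 4 is estimated at 24000 nM, within a range of 9000 nM to 60000 nM.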

Compound 4, concentration for 50% growth inhibition: 100000 nM
Estimate against measurement, compound 4: 4.2-fold (0.62 log units) below; the measured number lies above the stated range.
By their numbers in this assay, from the lowest: compound 1; then compounds 3, 2 and 4 (each within the scatter of the next).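

Thiophen-3-yl in place of thiophen-2-yl on the carbonyl carbon keeps the same ring atoms, yet the number rises (a 5.9-fold higher number from compound 1 to compound 4 (0.77 log units; beyond the scatter)), so at this position the sulfur-containing ring alone does not secure the low number of compound 1. The other two exchanges lie within the scatter (a 2.0-fold higher number from compound 3 to compound 4 (0.30 log units; within the scatter)) and (no change at the digits printed from compound 2 to compound 4 (within the scatter)), so thiophen-3-yl, 1,3-thiazol-5-yl and furan-3-yl cannot be separated here. Only thiophen-2-yl stands apart among the four groups.

Nothing in the data shown explains what sets thiophen-2-yl apart.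
From the compounds shown here alone, whether a phenyl group or an amine on the carbonyl carbon would give a number lower than that of compound 1 remains open.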